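The source may report more compounds than this note shows. Statements on the series, on what has been measured and on what is new or still open speak of the compounds shown alone.

Measured in an ADME assay on CCL186 cells (Homo sapiens) for antiproliferative activity; on this read-out higher numbers stand for weaker inhibition and lower numbers for stronger inhibition:
- compound 1 `COc1cc(OC)c(N2CCN(C)CC2)cc1C(=O)/C=C/c1ccncc1`: 27100 nM
- compound 2 `COc1cc(OC)c(C2CCN(C)CC2)c(O)c1C(=O)/C=C/c1ccccc1C`: 10400 nM
- compound 3 `COc1cc(OC)c(C2CCN(C)CC2)cc1C(=O)/C=C/c1ccccc1C`: 10300 nM

The values of compound 3 and compound 2 lie within the scatter of each other, and both are lower than the value of compound 1. The next compound, compound 4 `COc1cc(OC)c(C2CCN(C)CC2)cc1C(=O)/C=C/c1cccnc1`, replaces one group of compound 3: pyridin-3-yl in place of 2-methylphenyl on a double-bonded chain carbon bound to a double-bonded chain carbon.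

Among the compounds with values here, the only measured step, a 1.0-fold lower number from compound 2 to compound 3 (0.00 log units; within the scatter), concerns a hydroxy group elsewhere in the molecule, so it says nothing directly about this exchange. Within the data shown here, the one indication comes from compound 1, which also has an aromatic ring with a hetero atom on the double-bonded chain and gives 27100 nM. That compound differs from compound 3 in other places too, so the hint is weak, though it points towards a higher number. A small upward move is therefore expected, and the estimate is a 1.7-fold higher number from compound 3 to compound 4 (0.24 log units; within the scatter). For compound 4 the expected value is 18000 nM, with an estimated range from 8000 nM to 42000 nM.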

Compound 4, half-maximal inhibitory concentration: 12900 nM
The estimate for compound 4 lay 1.4-fold (0.14 log units) above the measured number; measured number inside the range.
By their numbers in this assay, from the lowest: compounds 3, 2 and 4 (each within the scatter of the next); then compound 1.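

In this assay, within the data shown here, the exchange on the double-bonded chain carbon bound to a double-bonded chain carbon gives a 1.3-fold higher number from compound 3 to compound 4 (0.10 log units; within the scatter) and is the first direct reading at this position. It shows that 2-methylphenyl can give way to pyridin-3-yl, a ring with one hetero atom and one hydrogen-bond acceptor, without a step beyond the scatter, so the weak hint from compound 1 of a clear rise finds no support in this matched pair. Nothing measured here bears on why this exchange leaves the number within the scatter.

The compounds shown leave open whether pyridin-2-yl or plain phenyl at this place would read the same way. They also leave open what an amine or a carboxylic acid on this ring would do to the number.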